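This account rests on a few compounds, and the source may have more. Where it says the series, first, only, none or still open, it means among the compounds named here.

In a functional assay on A-375 cells (Homo sapiens) for cytotoxicity, read by MTT assay, with a stated time of 72 h (a lower number here means a stronger inhibitor, a higher number a weaker inhibitor), compound 1 `O=C1c2c[n+]([O-])c3ccccc3c2C(=O)c2c1c1ccccc1n2Cc1cn(C[C@H](O)CO)nn1` gives 350 nM and compound 2 `O=C1c2c[n+]([O-])c3ccccc3c2C(=O)c2c1c1ccccc1n2Cc1cn(CC(O)CO)nn1` gives 440 nM on a core they share with compound 3 `CCCCN1CCN(CCCCn2c3c(c4ccccc42)C(=O)c2c[n+]([O-])c4ccccc4c2C3=O)CC1`. Compound 3 at 2150 nM has the highest of the three numbers, and its gap to each of the other two lies beyond the scatter.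

Compound 4 `O=C1c2c[n+]([O-])c3ccccc3c2C(=O)c2c1c1ccccc1n2CCN1CCCCC1` keeps the core of compound 3 and differs in one place, with piperidin-1-yl in place of 2-(4-butylpiperazin-1-yl)ethyl on a saturated chain carbon, two bonds along the chain from an aromatic nitrogen.

Among the measured compounds shown here, the only step measured so far (a 1.3-fold higher number from compound 1 to compound 2 (0.10 log units; within the scatter)) is small and concerns the fact that one of compounds 1 and 2 is drawn with a defined configuration and the other without, at the place where they differ alone, so it does not bear on this change of chain. What remains is the spread of values on this core: with other chains, compound 1 stands at 350 nM and compound 2 at 440 nM in this assay while compound 3 sits at the high end. A move towards a lower number is therefore expected, but its size is poorly constrained, and the estimated step is a 2.7-fold lower number from compound 3 to compound 4 (0.43 log units; beyond the scatter) as a rough guide only. For compound 4 the estimated value is 800 nM (expected range 220 nM to 3000 nM).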

Compound 4, half-maximal inhibitory concentration: 180 nM
Compound 4: the middle estimate sits 4.4-fold (0.65 log units) above what was measured; the measured number lies below the stated range.
By their numbers in this assay, from the lowest: compounds 4, 1 and 2 (each within the scatter of the next, the first and the last beyond it); then compound 3.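

Replacing 2-(4-butylpiperazin-1-yl)ethyl with piperidin-1-yl, on a saturated chain carbon two bonds along the chain from an aromatic nitrogen, gives a 12-fold lower number from compound 3 to compound 4 (1.08 log units; beyond the scatter) in this assay, so at this place on the shared core, piperidin-1-yl serves far better than 2-(4-butylpiperazin-1-yl)ethyl. The triazole-bearing chains give a split picture: the change to (piperidin-1-yl)methyl gives a 2.4-fold lower number from compound 2 to compound 4 (0.39 log units; beyond the scatter), but a 1.9-fold lower number from compound 1 to compound 4 (0.29 log units; within the scatter), so the two chain types cannot be firmly ranked, and the difference between them is less clear than the large step from the butylpiperazine chain. Nothing available explains why the smaller group does so much better.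

The step from compound 3 removes the butyl group, one ring nitrogen and part of the side chain all at once, and the compounds shown do not separate these contributions. A morpholine ring or a simple dimethylamino group in place of piperidin-1-yl, or a 4-butylpiperidin-1-yl group, would help show which of these parts drives the change.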